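This account rests on a few compounds, and the source may have more. Where it says the series, first, only, none or still open, it means among the compounds named here.

Working notes on the shared core of compound 1 `O=C1C=CCC(/C=C/c2ccccc2)N1`. In a functional assay on NCI-H460 cells (Homo sapiens) for inhibition, read by sulforhodamine B assay, with a stated time of 48 h (on this read-out lower numbers stand for stronger inhibition of growth and higher numbers for weaker inhibition of growth), compound 1 gives 929 uM. Compound 2 `O=C1C=CCC(/C=C/c2ccc(C(F)(F)F)cc2)N1` gives 150 uM in this assay, so the step of a 6.2-fold lower number from compound 1 to compound 2 (0.79 log units; beyond the scatter). Compound 3 `COc1ccc(/C=C/C2CC=CC(=O)N2)cc1` reaches only a limit in this assay, giving > 1090 uM. On the numbers shown, compound 3 stands at the limit of > 1090 uM in this assay, at which 1 of the 3 values shown sits, and therefore both the step of an at least 1.1-fold higher number from compound 1 to compound 3 (0.06 log units; that floor lies within the scatter) and the step of an at least 7.2-fold higher number from compound 2 to compound 3 (0.86 log units; beyond the scatter) are floors rather than settled sizes.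

Compound 4 `COc1ccc(/C=C/C2CC=CC(=O)N2)c(OC)c1` differs from compound 3 by methoxy in place of hydrogen on an aromatic carbon. Of the measured steps, the two that introduce a group onto the aromatic ring bear on it: the step of a 6.2-fold lower number from compound 1 to compound 2 (0.79 log units; beyond the scatter) and the step of an at least 1.1-fold higher number from compound 1 to compound 3 (0.06 log units; that floor lies within the scatter). The second of these, with the same entering group, produced no shift beyond the scatter, and compound 3 already sits at the limit, so no step beyond the scatter is expected in this assay from a second methoxy. The expected step is a step that the limit leaves unreadable from compound 3 to compound 4, none beyond the scatter. Compound 4 is estimated at 1500 uM, within a range from 700 uM to 5000 uM, and is most likely to be reported again only as a limit.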

Compound 4, concentration for growth inhibition (reported as GI): > 964 uM
Compound 4: no number, only a limit; the forecaster's own chance of this, stated with the estimate: 75%; the middle value does not contradict the limit.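

Compound 3 gives > 1090 uM in this assay, which is a limit. Among these compounds, compound 4 gives > 964 uM, also a limit, so no step between compound 3 and compound 4 can be read. The compounds shown leave open whether a second methoxy on the aromatic ring changes growth inhibition at all, and in which direction.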